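A few compounds are considered here, and "the series" means these few. Any claim that something is new, unique, unknown or untested is made for them only; others in the source may bear on it.

Compound 1 `CCc1nnc(NS(=O)(=O)c2ccc(NC(=O)Nc3ccc(C(F)(F)F)cc3)cc2)s1` gives 10000 nM in an assay on Sf9 cells for displacement of a labelled ligand from P2Y purinoceptor 1 (Homo sapiens); on this read-out higher numbers stand for weaker inhibition and lower numbers for stronger inhibition.
Compound 2 `Cc1noc(NS(=O)(=O)c2ccc(NC(=O)Nc3ccc(C(F)(F)F)cc3)cc2)c1C` gives 45000 nM in this assay.
Compound 3 `Cc1noc(NS(=O)(=O)c2ccc(NC(=O)Nc3cccc(Cl)c3)cc2)c1C` reaches only the limit of >= 100000 nM in this assay.

All three share the same core carrying a urea and a sulfonamide. The step of a 4.5-fold higher number from compound 1 to compound 2 (0.65 log units; beyond the scatter) shows that exchanging the heterocycle on the sulfonamide nitrogen costs a modest amount of binding. The step of an at least 2.2-fold higher number from compound 2 to compound 3 (0.34 log units; beyond the scatter) shows that exchanging the aryl group on the urea nitrogen costs at least a modest amount more, and compound 3 ends at the limit (the limit of >= 100000 nM in this assay, at which 1 of the 3 values shown sits); for compound 3 only this limit is known, not a number.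

Compound 4 `Cc1noc(NS(=O)(=O)c2ccc(NC(=O)Nc3cc(F)cc(F)c3)cc2)c1C` has not yet been measured in this assay. It differs from compound 3 by 3,5-difluorophenyl in place of 3-chlorophenyl on an amide-type nitrogen. For the measured compounds named here, the only measured step that bears on this position is an at least 2.2-fold higher number from compound 2 to compound 3 (0.34 log units; beyond the scatter), which went in the direction of weaker binding, and compound 3 already sits at the limit. Going by the values given here, nothing among the measured compounds points to a recovery from changing this aryl group again. Compound 4 is therefore expected to stay close to the limit, with an estimated step of a number no higher from compound 3 to compound 4 (the limit leaves the size open). The estimate for compound 4 is 100000 nM, within a range of 30000 nM to 300000 nM.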

Compound 4, inhibition constant: >= 100000 nM
Compound 4: no number, only a limit; the forecaster's own chance of this, stated with the estimate: 65%; the middle value lies on the limit itself.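

In this assay compound 4, like compound 3, gives only a limit and not a number, so a second replacement of the aryl group on this amide-type nitrogen ends in the same place as the first: the limit of >= 100000 nM in this assay, at which 2 of the 4 values shown sit.

Set against the 4-(trifluoromethyl)phenyl group, 3,5-difluorophenyl gives an at least 2.2-fold higher number from compound 2 to compound 4 (0.34 log units; beyond the scatter), so the loss of binding seen with 3-chlorophenyl is not tied to that one group. As far as these compounds go, the step from compound 3 to compound 4 cannot be read, since both values are limits, and the order of 3-chlorophenyl and 3,5-difluorophenyl stays unknown.

From the compounds shown here alone, it remains open whether any replacement for 4-(trifluoromethyl)phenyl on this nitrogen keeps binding at all, for instance a benzyl or a cyclohexyl group, or a phenyl ring carrying a carboxylic acid. Going by these compounds, it also remains open whether 3,5-difluorophenyl would read as a number if paired with the 5-ethyl-1,3,4-thiadiazol-2-yl group on the sulfonamide nitrogen, the group that compound 1 carries.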